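The source may hold more compounds than are shown below. What is called first, only, known or untested is meant among the compounds shown, and "the series" means these compounds.

Compound 1 `C=C1CCC[C@H]2[C@](C)(CC[C@]3(C)CC[C@H]([C@@H](C)C(=O)O)OO3)[C@@H](C)CC[C@]12C` carries a cyclic peroxide side chain on a fused tricyclic core, and in a functional assay on KM12 cells (Homo sapiens) for cytotoxicity, read by colony formation (on this read-out higher numbers stand for weaker inhibition of growth and lower numbers for stronger inhibition of growth), compound 1 gives 940 nM. Compound 2 `C=C1CCCC(C)(C)C1CC[C@@]1(C)CC[C@H]([C@@H](C)C(=O)O)OO1` keeps the peroxide ring and the acid-bearing side chain but sits on a smaller, monocyclic core, and in this assay compound 2 gives 4820 nM, the highest number of the two measured compounds; the gap to compound 1 is beyond the usual scatter, so compound 2 is the weaker inhibitor of growth of the pair. Compound 3 `C=C1CCCC(C)(C)C1CC[C@]1(C)CC[C@@H]([C@@H](C)C(=O)O)OO1` has the same atoms and bonds as compound 2 and differs only in drawn configuration: the two compounds have the same atoms and bonds; at least one stereo element is drawn with a configuration in one of them and without one in the other: 2 of 4 stereo elements differ; a stereocentre at a saturated ring carbon is drawn S in compound 2 and R in compound 3; a stereocentre at a saturated ring carbon is drawn R in compound 2 and S in compound 3. Going by the values given here, no step between measured compounds mirrors this change, so its size and direction can only be guessed. The inversion touches the peroxide ring itself, so a shift in either direction is plausible. With nothing to anchor it, the expected step is a 1.4-fold lower number from compound 2 to compound 3 (0.14 log units; within the scatter), close to none beyond the scatter. Compound 3 is therefore estimated at 3500 nM, with a range from 900 nM to 14000 nM.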

Compound 3, concentration for 50% growth inhibition: > 5000 nM
Compound 3 ended at the assay's limit; the forecaster's own chance of this, stated with the estimate: 5%; middle value at least 1.4-fold (0.15 log units) from the limit.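

In this assay compound 3 gives > 5000 nM, which is a limit of the assay and not a number. The step therefore has only a floor, an at least 1.0-fold higher number from compound 2 to compound 3 (0.01 log units; that floor lies within the scatter), so the change at these two stereocentres on saturated ring carbons cannot be sized, and the data establish no difference in either direction, although they do show that compound 3 did not reach a measurable number in this assay, unlike compound 2. This comparison also cannot be read as a clean swap of one defined configuration for its opposite, and a caution applies: the fact that one of compounds 2 and 3 is drawn with a defined configuration and the other without, at the place where they differ

The compounds shown leave open how far beyond the limit compound 3 lies, and whether the same change in configuration on the peroxide ring would move the number of compound 1, with its larger core, in this assay. They also leave open what a methyl ester or a primary amide in place of the carboxylic acid would do to either configuration.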